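Replacing naphthalen-2-yl with 3-iodophenyl on a carbonyl carbon

This account rests on a few compounds, and the source may have more. Where it says the series, first, only, none or still open, it means among the compounds named here.

Measured so far in a functional assay on MDA-MB-231 cells (Homo sapiens) for antiproliferative activity, read by MTT assay, with a stated time of 24 h (on this read-out lower numbers stand for stronger inhibition and higher numbers for weaker inhibition), are three compounds:
- Compound 1 `COC(=O)c1scc(-c2ccc(NC(=O)c3ccc4ccccc4c3)cc2)c1OC` gives 5250 nM
- Compound 2 `COC(=O)c1scc(-c2ccc(NC(=O)c3ccccn3)cc2)c1OC` gives 8250 nM
- Compound 3 `COC(=O)c1scc(-c2ccc(NC(=O)c3ccc(C(F)(F)F)cc3Br)cc2)c1OC` gives 19600 nM

Compound 1 sits at the low end of this small set, level within the scatter with compound 2, while compound 3 stands clearly higher than compound 1. Compound 4 `COC(=O)c1scc(-c2ccc(NC(=O)c3cccc(I)c3)cc2)c1OC` has not yet been measured. It keeps the core of compound 1 and differs at one place (3-iodophenyl in place of naphthalen-2-yl on a carbonyl carbon), with 3-iodophenyl in place of naphthalen-2-yl on a carbonyl carbon. Among the measured compounds shown here, the only measured step at this place is a 1.6-fold higher number from compound 1 to compound 2 (0.20 log units; within the scatter) and it stays within the scatter, although pyridin-2-yl replaces naphthalen-2-yl there. Compound 3, at 19600 nM in the same series, shows how far the number can rise, so the upper side is left wider. No step beyond the scatter is therefore expected in this assay and any drift is expected to be upward. An expected step of a 1.5-fold higher number from compound 1 to compound 4 (0.18 log units; within the scatter) is the working estimate. The estimate for compound 4 is 8000 nM (expected range 3500 nM to 20000 nM).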

Compound 4, half-maximal inhibitory concentration: 8240 nM
Estimate against measurement, compound 4: 1.0-fold (0.01 log units) below; the range from low to high includes it.
By their numbers in this assay, from the lowest: compounds 1, 4 and 2 (each within the scatter of the next); then compound 3.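

In this assay the change from the two rings of naphthalen-2-yl to the single ring of 3-iodophenyl gives a 1.6-fold higher number from compound 1 to compound 4 (0.20 log units; within the scatter) and so stays within the scatter. Among the compounds shown here, the exchange of pyridin-2-yl for 3-iodophenyl gives a 1.0-fold lower number from compound 2 to compound 4 (0.00 log units; within the scatter) and also stays within the scatter, so three different aromatic groups on this carbonyl carbon now read alike, where earlier only one such pair could be compared. No measurement offered here accounts for this likeness.

The compounds shown leave open how a plain phenyl would read at this place, and therefore whether the iodine matters at all. They also leave open whether a group bearing an amine or a carboxylic acid, or a longer alkyl chain, would stay level with these three.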